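A few compounds are considered here, and "the series" means these few. Any claim that something is new, unique, unknown or untested is made for them only; others in the source may bear on it.

Measured compounds:
- compound 1, `CCCC(=O)OCSc1ccccc1C(=O)NCCCC(N)=O`: 56.6 uM
- compound 2, `CCCC(=O)OC[Se]c1ccccc1C(=O)NCC(N)=O`: 6.8 uM

In an ADME assay on CEM-SS cells (Homo sapiens) for cytotoxicity, read by XTT assay, with a stated time of 6 days (a higher number here means that more compound is tolerated, a lower number that less compound is tolerated), compound 1 gives 56.6 uM, the higher of the two numbers; compound 2 gives 6.8 uM, a lower number by a margin that lies beyond the scatter. The two differ in more than one place, so their values are reported side by side without a computed step.

Compound 3, `CCCC(=O)OCSc1ccccc1C(=O)NCC(=O)N(C)C`, has not yet been measured in this assay. It is built from the same atoms as compound 1, joined differently: dimethylcarbamoyl in place of 2-carbamoylethyl on a saturated chain carbon bound to an amide-type nitrogen. Among the measured compounds shown here, no measured pair shows this kind of change, so there is no basis for a step of any particular size. The account therefore expects a step from compound 1 to compound 3 in this assay of a 1.3-fold lower number from compound 1 to compound 3 (0.10 log units; within the scatter), that is, none beyond the scatter. For compound 3 the estimate in this assay is 45 uM, with a range from 18 uM to 110 uM.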

Compound 3, half-maximal toxic concentration: 38.3 uM
The estimate for compound 3 lay 1.2-fold (0.07 log units) above the measured number; measured number inside the range.
By their numbers in this assay, from the lowest: compound 2; then compounds 3 and 1 (each within the scatter of the next).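

Among the compounds shown here, this is the first step that can be read at this position: in this assay, dimethylcarbamoyl in place of 2-carbamoylethyl on a saturated chain carbon bound to an amide-type nitrogen gives a 1.5-fold lower number from compound 1 to compound 3 (0.17 log units; within the scatter). The two groups hold the same atoms joined differently, and the count of hydrogen-bond donors goes from 1 to 0, yet the two compounds stay within the scatter of each other in this assay. No measurement shown here bears on why this is so.

Going by these compounds, whether a carboxylic acid, an amine or a longer chain at this place would give a step beyond the scatter remains open. Compound 2, at 6.8 uM, differs from compound 1 and from compound 3 in more than one place, so its number cannot be assigned to any single part of its structure.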